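Ethyl on the Anilino Nitrogen of a Weak Binder

The source may hold more compounds than are shown below. What is called first, only, known or untested is meant among the compounds shown, and "the series" means these compounds.

Compound 1: `CCCN(Cc1sc(Nc2c(Br)cc(Br)cc2Br)nc1C(F)(F)F)CC1CC1` — 7.8 nM
Compound 2: `CCCN(Cc1sc(Nc2ccc(C(C)C)cc2Br)nc1C(F)(F)F)CC1CC1` — 2900 nM

In an assay for displacement of a labelled ligand from corticotropin-releasing factor receptor 1 (Homo sapiens) (on this read-out higher numbers stand for weaker inhibition and lower numbers for stronger inhibition), compound 1 gives 7.8 nM. Compound 2 gives 2900 nM in this assay, the higher of the two numbers and beyond the scatter from compound 1. Compound 3, `CCCN(Cc1sc(N(CC)c2ccc(C(C)C)cc2Br)nc1C(F)(F)F)CC1CC1`, differs from compound 2 by ethyl in place of hydrogen on a nitrogen on an aromatic ring. Within the data shown here, no measured pair shows such a change, so no direction is known from these data. The step is expected to be small, a 1.5-fold lower number from compound 2 to compound 3 (0.16 log units; within the scatter), within or near the scatter. Compound 3 is estimated to give 2000 nM in this assay, in the range 400 nM to 10000 nM.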

Compound 3, inhibition constant: 56 nM
Compound 3: middle estimate off by 36-fold (1.55 log units), on the high side; measured number outside the range, below it.
By their numbers in this assay, from the lowest: compound 1; then compound 3; then compound 2.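

Ethyl in place of hydrogen on a nitrogen on an aromatic ring moves the number in this assay a long way (a 52-fold lower number from compound 2 to compound 3 (1.71 log units; beyond the scatter)), toward stronger inhibition. Compound 1 and compound 2 both carry hydrogen there, so they could not show that this nitrogen responds to substitution at all. Nothing available explains the size of this step.

From the compounds shown here alone, whether methyl, a longer chain such as propyl, or a carboxylic acid on this nitrogen would act like ethyl remains open. So does whether ethyl on the same nitrogen of compound 1 would bring a comparable step.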